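A few compounds are considered here, and "the series" means these few. Any claim that something is new, unique, unknown or untested is made for them only; others in the source may bear on it.

Working notes on the series. In a functional assay on HCT-116 cells (Homo sapiens) for inhibition, read by sulforhodamine B assay, with a stated time of 48 h (on this read-out lower numbers stand for stronger inhibition of growth and higher numbers for weaker inhibition of growth), compound 1 (`O=C(CCCCN1C/C=C/CCOc2cccc(c2)-c2ccnc(n2)Nc2cccc(c2)C1)NO`) gives 1530 nM and compound 2 (`O=C(CCCCCCN1C/C=C/COCc2cccc(c2)-c2ccnc(n2)Nc2cccc(c2)C1)NO`) gives 900 nM on the same read-out. Going by the values given here, these two values lie within the scatter of each other, so compound 1 stands level with the only other measured compound.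

Compound 3 (`O=C(CCCCC(=O)N1C/C=C/CCOc2cccc(c2)-c2ccnc(n2)Nc2cccc(c2)C1)NO`) departs from compound 1 in one place: (4-(hydroxycarbamoyl)butyl)carbonyl stands in place of 4-(hydroxycarbamoyl)butyl on an amine nitrogen in a ring ((4-(hydroxycarbamoyl)butyl)carbonyl in place of 4-(hydroxycarbamoyl)butyl on an amine nitrogen in a ring).

Among the compounds with values here, no measured pair isolates this change, so nothing sizes it directly. Within the data shown here, the one guide is that compound 1 at 1530 nM and compound 2 at 900 nM stay within the scatter of each other, which gives no ground to expect a large shift. In this assay a step no larger than the scatter is therefore expected, with no firm direction, and the range is kept wide on both sides. The expected step is a 1.0-fold lower number from compound 1 to compound 3 (0.01 log units; within the scatter) as an estimate only. For compound 3 the estimated value is 1500 nM within an expected range from 500 nM to 4500 nM for this working estimate.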

Compound 3, concentration for 50% growth inhibition: 1590 nM
For compound 3 the middle estimate is 1.1-fold (0.03 log units) below the measured one, within the range that was stated.
By their numbers in this assay, from the lowest: compounds 2, 1 and 3 (each within the scatter of the next).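

Read in this assay, replacing 4-(hydroxycarbamoyl)butyl with (4-(hydroxycarbamoyl)butyl)carbonyl on the amine nitrogen in a ring gives a 1.0-fold higher number from compound 1 to compound 3 (0.02 log units; within the scatter), the first measured step in the series that isolates a single change. At this position, therefore, the carbonyl can join the chain to the ring nitrogen while the two compounds stand level on growth inhibition, even though the hydrogen-bond acceptor count of the group rises from 2 to 3 and its donor count stays at 2. No measurement here bears on why the two compounds stand level.

Going by these compounds, it remains open whether this level holds when (4-(hydroxycarbamoyl)butyl)carbonyl is given a longer chain between the carbonyl and the hydroxycarbamoyl group, or when a carboxylic acid stands in place of the hydroxycarbamoyl group. Also open, on these data alone, is whether compound 1 and compound 3 stand level on any read-out other than this assay, since this single pair speaks only to growth inhibition in one cell line.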